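Adding methoxy to compound 1

A few compounds are considered here, and "the series" means these few. Any claim that something is new, unique, unknown or untested is made for them only; others in the source may bear on it.

For the measured compounds named here, compound 1 `Cc1nc2ccccc2c2c1O[C@]1(CC2)C[C@H]2C(=O)N[C@]3(C(=O)NS(=O)(=O)C4(C)CC4)C[C@H]3/C=C\CCCCC[C@H](NC(=O)OC(C)(C)C)C(=O)N2C1` holds the lower of the two numbers so far: in an ADME assay on the whole organism for pharmacokinetics, with Rattus norvegicus as the target, with a stated time of 24 h, at a dose of 5 mg/kg by the oral route (on this read-out higher numbers stand for higher exposure at the dose given and lower numbers for lower exposure), compound 1 gives 105 ng.h/mL, whereas compound 2 `CC(C)(C)OC(=O)N[C@H]1CCCCC/C=C\[C@@H]2C[C@@]2(C(=O)NS(=O)(=O)C2(C)CC2)NC(=O)[C@@H]2C[C@]3(CCc4c(c(C5CC5)nc5ccccc45)O3)CN2C1=O` gives 1550 ng.h/mL. Compound 3 `COc1ccc2nc(C)c3c(c2c1)CC[C@]1(C[C@H]2C(=O)N[C@]4(C(=O)NS(=O)(=O)C5(C)CC5)C[C@H]4/C=C\CCCCC[C@H](NC(=O)OC(C)(C)C)C(=O)N2C1)O3` keeps the core of compound 1 and alters one thing: methoxy in place of hydrogen on an aromatic carbon. Going by the values given here, only one measured step bears on this, a 15-fold higher number from compound 1 to compound 2 (1.17 log units; beyond the scatter), a large one, with cyclopropyl in place of methyl on an aromatic carbon. Among the compounds with values here, that step involves other groups, so it shows only that one small change to this core can move this assay strongly. It does not show what methoxy will do. Within the data shown here, with no measured methoxy step, the expected result is a 1.4-fold higher number from compound 1 to compound 3 (0.15 log units; within the scatter), with no clear shift beyond the scatter. For compound 3 the estimated value is 150 ng.h/mL, within an expected range of 45 ng.h/mL to 500 ng.h/mL.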

Compound 3, area under the concentration-time curve: 62.4 ng.h/mL
Estimate against measurement, compound 3: 2.4-fold (0.38 log units) above, and the stated range covers the measured number.
By their numbers in this assay, from the lowest: compounds 3 and 1 (each within the scatter of the next); then compound 2.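

This position shows the first measured result for a new group on the carbon-only aromatic ring: methoxy, meta to a fused ring and para to a fused ring, gives a 1.7-fold lower number from compound 1 to compound 3 (0.23 log units; within the scatter) in this assay. The oral exposure of the core of compound 1 therefore shows no clear shift with this change, whereas the swap of methyl for cyclopropyl gave a 15-fold higher number from compound 1 to compound 2 (1.17 log units; beyond the scatter). No supporting measurement is available to explain why methoxy leaves the number within the scatter.

From the compounds shown here alone, it remains open whether an amine, a carboxylic acid or a longer chain such as butoxy at this same carbon would shift the exposure. Also open, going by these compounds, is whether methoxy would give a similar result on the other carbons of this ring, or when added to compound 2.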